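Swapping Bromo for Methyl on Compound 2

This account rests on a few compounds, and the source may have more. Where it says the series, first, only, none or still open, it means among the compounds named here.

Results in a functional assay on PC-3 cells (Homo sapiens) for antiproliferative activity, read by MTT assay, with a stated time of 72 h; on this read-out lower numbers stand for stronger inhibition and higher numbers for weaker inhibition:
- compound 1 `C#CCSc1nc(Sc2nc(C)c(C)s2)c(C#N)c(-c2cc(OC)c(OC)c(OC)c2)n1`: > 20000 nM
- compound 2 `C#CCSc1nc(Sc2nccs2)c(C#N)c(-c2ccc(Br)cc2)n1`: 8530 nM
- compound 3 `C#CCSc1nc(Sc2nnnn2CCN(C)C)c(C#N)c(-c2cccc(Cl)c2)n1`: 3540 nM

Compound 1 has the entry > 20000 nM, which is a limit of the assay and not a number. Of the two true numbers, compound 2 has the higher, 8530 nM, and compound 3 lies lower at 3540 nM, a gap beyond the usual scatter.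

Compound 4 `C#CCSc1nc(Sc2nccs2)c(C#N)c(-c2ccc(C)cc2)n1` is still unmeasured. It differs from compound 2 in one place: methyl in place of bromo on an aromatic carbon. Among the compounds with values here, no measured pair isolates this swap, so the expectation starts from compound 2 at 8530 nM and foresees no step beyond the scatter in this assay. The expected step is a 1.1-fold lower number from compound 2 to compound 4 (0.03 log units; within the scatter). For compound 4 the estimated value is 8000 nM, with an expected range from 3000 nM to 20000 nM.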

Compound 4, half-maximal inhibitory concentration: 1620 nM
For compound 4 the middle estimate is 4.9-fold (0.69 log units) above the measured one; the whole stated range lies above it.
By their numbers in this assay, from the lowest: compound 4; then compound 3; then compound 2. At a limit, above all of these: compound 1.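

In this assay, within the data shown here, the change from 4-bromophenyl to 4-methylphenyl gives a 5.3-fold lower number from compound 2 to compound 4 (0.72 log units; beyond the scatter) and is the first single-place comparison in this set. It shows that this aromatic carbon is not indifferent to which group it carries, since replacing one heavy atom with another alters antiproliferative potency beyond the usual scatter. No measurement shown here explains why methyl outperforms bromo at this position.

Going by these compounds, how an amine, a carboxylic acid or a longer chain such as propyl would fare at this carbon remains open. So does whether the methyl gain carries over when the thiazole-bearing side of the molecule is changed.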